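Positional isomer of the pyridyl arm: cytotoxicity outlook

The source may report more compounds than this note shows. Statements on the series, on what has been measured and on what is new or still open speak of the compounds shown alone.

Compound 2 `CSc1ccc(C(=O)/C(=C/c2cccnc2)c2ccc(Cl)c(Cl)c2)cc1` shows in an ADME assay on Vero cells (Chlorocebus sabaeus) for cytotoxicity, read by MTT assay, tested at 25 uM (a lower number here means a stronger effect, a higher number a weaker effect of the compound at the concentration tested), a read-out of 95.7%. Among the two numbers at hand this is the highest, but its only neighbour, compound 1 `CSc1ccc(C(=O)/C(=C/c2cc3ccccc3s2)c2ccc(Cl)c(Cl)c2)cc1`, gives 93.4%, and the step of a number 2.3 percentage points higher from compound 1 to compound 2 (within the scatter) is within the scatter, so the two cannot be ordered.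

Compound 3 `CSc1ccc(C(=O)/C(=C/c2ccccn2)c2ccc(Cl)c(Cl)c2)cc1` has not been measured. It differs from compound 2 in one place: pyridin-2-yl in place of pyridin-3-yl on a double-bonded chain carbon bound to a double-bonded chain carbon.

Among the compounds with values here, no measured step swaps one pyridyl for another, so the only precedent is the move from compound 1 to compound 2, where a much larger exchange of the aromatic arm at the same place left the read-out essentially unchanged. Both known values sit near the top of the scale, leaving little room for a higher number. The expectation for compound 3 is therefore no step beyond the scatter, the estimated step being a number 1.7 percentage points lower from compound 2 to compound 3 (within the scatter). For compound 3 the estimated read-out is 94%, with a range from 84% to 100%.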

Compound 3, a percentage reported as activity, at one concentration (the size of the read-out at that concentration, not a potency): 97.9%
Compound 3: middle estimate off by 3.9 percentage points, on the low side, and the stated range covers the measured number.
By their numbers in this assay, from the lowest: compounds 1, 2 and 3 (each within the scatter of the next).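

Exchanging pyridin-3-yl for pyridin-2-yl on a double-bonded chain carbon bound to a double-bonded chain carbon gives a number 2.2 percentage points higher from compound 2 to compound 3 (within the scatter) in this assay and so does not separate two compounds that have the same atoms, joined differently. The wider exchange at the same place, pyridin-2-yl in place of 1-benzothiophen-2-yl, gives a number 4.5 percentage points higher from compound 1 to compound 3 (within the scatter) and adds a second pair that cannot be ordered, so the three aromatic arms shown here cannot be told apart in this assay and no preference among them can be drawn at this place. Nothing at hand bears on why the read-out stays so flat across these arms.

On these data alone, all three arms are aromatic rings, so it remains open how this assay would respond at this place to a group of another kind, such as an aliphatic amine, a carboxylic acid or a longer alkyl chain. As far as these compounds go, the rest of the shared core is identical in all three compounds, so it is also open whether a change elsewhere, for instance an added amine, would move the read-out beyond the scatter.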